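Capping the Pyrrolidine Nitrogen: From Amide to Carbamate

This account rests on a few compounds, and the source may have more. Where it says the series, first, only, none or still open, it means among the compounds named here.

Three measured compounds share one core and differ only on the amine nitrogen in a ring. In a functional assay on HCC827 cells (Homo sapiens) for antiproliferative activity, read by MTT assay, with a stated time of 72 h (on this read-out higher numbers stand for weaker inhibition and lower numbers for stronger inhibition), compound 1 `CN1CCN(c2ccc(Nc3ncc4nc(Nc5ccccc5)n([C@H]5CCN(S(C)(=O)=O)C5)c4n3)cc2)CC1` gives 17 nM, compound 2 `CN1CCN(c2ccc(Nc3ncc4nc(Nc5ccccc5)n([C@H]5CCNC5)c4n3)cc2)CC1` gives 530 nM, and compound 3 `CNC(=O)CN1CC[C@H](n2c(Nc3ccccc3)nc3cnc(Nc4ccc(N5CCN(C)CC5)cc4)nc32)C1` gives 170 nM. Compound 3 thus stands second highest of the three: its nearest neighbour is compound 2, with a 3.1-fold lower number from compound 2 to compound 3 (0.49 log units; beyond the scatter), and its furthest is compound 1, with a 10-fold higher number from compound 1 to compound 3 (1.00 log units; beyond the scatter). The step of a 31-fold higher number from compound 1 to compound 2 (1.49 log units; beyond the scatter) shows how much the bare amine costs.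

Compound 4 `CN1CCN(c2ccc(Nc3ncc4nc(Nc5ccccc5)n([C@@H]5CCN(C(=O)OC(C)(C)C)C5)c4n3)cc2)CC1` carries 1-(tert-butoxycarbonyl)pyrrolidin-3-yl in place of 1-((methylcarbamoyl)methyl)pyrrolidin-3-yl on an aromatic nitrogen. Within the data shown here, the steps that bear on it are those from compound 1 and from compound 2 to compound 3: an acyl-type cap on that nitrogen has so far given lower numbers than hydrogen, and the methylsulfonyl of compound 1 lower still. Compound 4 is therefore expected to show a modest lowering, a 2.1-fold lower number from compound 3 to compound 4 (0.33 log units; beyond the scatter), in this assay. Compound 4 is estimated at 80 nM, with a range from 15 nM to 400 nM.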

Compound 4, half-maximal inhibitory concentration: 12 nM
Estimate against measurement, compound 4: 6.7-fold (0.82 log units) above; the measured number lies below the stated range.
By their numbers in this assay, from the lowest: compounds 4 and 1 (each within the scatter of the next); then compound 3; then compound 2.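

In this assay the 1-(tert-butoxycarbonyl)pyrrolidin-3-yl group gives a 14-fold lower number from compound 3 to compound 4 (1.15 log units; beyond the scatter) and also a 44-fold lower number from compound 2 to compound 4 (1.65 log units; beyond the scatter) on the same position, so a carbamate cap on the ring nitrogen can lower the number far more than the earlier amide-bearing cap did. Against the methylsulfonyl cap there is a 1.4-fold lower number from compound 1 to compound 4 (0.15 log units; within the scatter) and the two caps cannot be told apart here, which shows that a low number at this position does not depend on methylsulfonyl alone. Nothing available explains why these caps differ from the (methylcarbamoyl)methyl group of compound 3.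

Open is whether the size of the tert-butyl part matters, since a smaller methyl carbamate or a plain acetyl on that nitrogen is not among these compounds. Also open, going by these compounds, is how the other hand of the defined stereocentre would read with each cap.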